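Notes on the 4-bromophenyl analogue of compound 1

This account rests on a few compounds, and the source may have more. Where it says the series, first, only, none or still open, it means among the compounds named here.

Measured so far in a functional assay, read by Griess assay, with a stated time of 2.5 h; a lower number here means a stronger inhibitor, a higher number a weaker inhibitor
compound 1 (`COc1cc(OC)c(OC)cc1/C=C/C(=O)c1ccc(C)cc1`) gives 2.18 ug/mL
compound 2 (`COc1cc(OC)c(C(=O)/C=C/c2cc(OC)c(OC)cc2OC)c(OC)c1`) gives 1.98 ug/mL
compound 3 (`COc1cc(OC)c(C2CC(=O)c3cc(O)ccc3O2)cc1OC`) gives 2.43 ug/mL

On these numbers compound 1 has no separate standing. Compound 1 at 2.18 ug/mL lies within the scatter of both compound 2 and compound 3, and those two also lie within the scatter of each other. Among the compounds with values here, the three structures differ in more than one place, so no measured pair isolates a single change.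

The next entry is compound 4 (`COc1cc(OC)c(OC)cc1/C=C/C(=O)c1ccc(Br)cc1`), which keeps the core of compound 1 and carries bromo in place of methyl on an aromatic carbon, para to a large group (bromo in place of methyl on an aromatic carbon). The same difference reads 4-methylphenyl to 4-bromophenyl.

Within the data shown here, the data hold no measured example of this exchange, so no direction is favoured and no step beyond the scatter is expected in this assay here. The expectation is anchored on compound 1 at 2.18 ug/mL and on nothing firmer, since three compounds are too few to establish a pattern. The estimated size of the change is a 1.0-fold higher number from compound 1 to compound 4 (0.00 log units; within the scatter) and so none beyond the scatter. For compound 4 the expected value is 2.2 ug/mL with an estimated range from 1.2 ug/mL to 4 ug/mL for now.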

Compound 4, half-maximal inhibitory concentration: 2.22 ug/mL
Estimate against measurement, compound 4: 1.0-fold (0.00 log units) below, within the range that was stated.
By their numbers in this assay, from the lowest: compounds 2, 1, 4 and 3 (each within the scatter of the next).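

In this assay, within the data shown here, the pair of compound 1 and compound 4 gives the series its only step that isolates one change: bromo in place of methyl on an aromatic carbon, para to a large group, gives a 1.0-fold higher number from compound 1 to compound 4 (0.01 log units; within the scatter). At this position the 4-methylphenyl and 4-bromophenyl forms are therefore not told apart by this read-out, and the position accepts this one exchange without a step beyond the scatter. No measured evidence bears on this result, and the step stands here without an explanation.

A single exchange at a single position does not show whether other groups placed there, such as an amine, a carboxylic acid or a longer chain like butyl, would also stay within the scatter or would give a real step in either direction. The methoxy groups on the other side of the core of compound 1 also remain open, since no pair among the compounds shown changes one of them alone.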